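This account rests on a few compounds, and the source may have more. Where it says the series, first, only, none or still open, it means among the compounds named here.

Working notes on the series. For the measured compounds named here, in an ADME assay on microsomes from liver (Mus musculus) for metabolic stability, with a stated time of 10 min (on this read-out higher numbers stand for a more stable compound and lower numbers for a less stable compound), compound 1 (`CO[C@]1(C(=O)N2CC[C@](c3ccc(C(F)(C(F)(F)F)C(F)(F)F)cc3)(S(=O)(=O)c3ccc(F)cc3)C2)CC[C@H](C(=O)O)CC1`) gives 95%, the higher of the two numbers so far, and compound 2 (`O=C(O)C12CCC(C(=O)N3CC[C@](c4ccc(C(F)(C(F)(F)F)C(F)(F)F)cc4)(S(=O)(=O)c4ccc(F)cc4)C3)(CC1)CC2`) gives 73%. Compound 3 (`O=C([C@H]1CC[C@H](c2nnn[nH]2)CC1)N1CC[C@](c2ccc(C(F)(C(F)(F)F)C(F)(F)F)cc2)(S(=O)(=O)c2ccc(F)cc2)C1`) is unmeasured. It carries 4-(1H-tetrazol-5-yl)cyclohexyl in place of 4-carboxy-1-methoxycyclohexyl on a carbonyl carbon. Going by the values given here, the only measured change at this place is a number 22 percentage points lower from compound 1 to compound 2 (beyond the scatter), though with a different entering group, so it is a loose guide. A similar drop is expected, estimated as a number 17 percentage points lower from compound 1 to compound 3 (beyond the scatter). In this assay the estimate for compound 3 is 78%, with an expected range of 58% to 93%.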

Compound 3, percent of the compound remaining: 73%
Compound 3: middle estimate off by 5 percentage points, on the high side; low and high end bracket the measured number.
By their numbers in this assay, from the lowest: compounds 2 and 3 (each within the scatter of the next); then compound 1.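

In this assay, a second replacement of 4-carboxy-1-methoxycyclohexyl on this carbonyl carbon also gives a lower number (a number 22 percentage points lower from compound 1 to compound 3 (beyond the scatter)), so the drop is not unique to the group in compound 2. The carboxy group is gone here as well, replaced by 1H-tetrazol-5-yl, yet the two replacements stand level (no change at the digits printed from compound 2 to compound 3 (within the scatter)). No supporting data explain these numbers. Open, from the compounds shown here alone, is whether the methoxy or the carboxy group of compound 1 accounts for the difference. A 4-carboxycyclohexyl group, without the methoxy, would separate the two.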